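Tetrahydropyridine replacing chlorobenzylamino on the pyridine core

The source may hold more compounds than are shown below. What is called first, only, known or untested is meant among the compounds shown, and "the series" means these compounds.

Compound 2 `CC(C(=O)NCc1ccc(C(F)(F)F)nc1NCc1ccc(Cl)cc1)c1ccc(NS(C)(=O)=O)c(F)c1` gives 414 nM in a functional assay on CHO-K1 cells for antagonist activity at transient receptor potential cation channel subfamily V member 1 (Homo sapiens), read by FLIPR (on this read-out higher numbers stand for weaker inhibition and lower numbers for stronger inhibition), the highest number of the three measured compounds. Within the data shown here, compound 1 `CC(C(=O)NCc1ccc(C(F)(F)F)nc1NCc1ccccc1)c1ccc(NS(C)(=O)=O)c(F)c1` gives 203 nM in this assay, and the step of a 2.0-fold higher number from compound 1 to compound 2 (0.31 log units; beyond the scatter) is the only measured change that touches the same position. Among the measured compounds shown here, compound 3 `C[C@H](C(=O)NCc1ccc(C(F)(F)F)nc1N1CC[C@@H](OCc2ccccc2)C1)c1ccc(NS(C)(=O)=O)c(F)c1` gives 50 nM in this assay; no single-point step links it to compound 2, and the two values only show that a cyclic amine on the core can go with a low number.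

Compound 4 `CC(C(=O)NCc1ccc(C(F)(F)F)nc1N1CC=CCC1)c1ccc(NS(C)(=O)=O)c(F)c1` is made from compound 2 by the change (a group of 6 heavy atoms (5 carbon, 1 nitrogen; one six-membered non-aromatic ring with 1 hetero atom) in place of a group of 9 heavy atoms (7 carbon, 1 nitrogen, 1 chlorine; one six-membered aromatic ring of carbon only), on an aromatic carbon). For the measured compounds named here, no measured pair covers the removal of the aromatic ring together with the loss of the donor, so the step from compound 1 to compound 2 bears on it only indirectly, and compound 3 only loosely. The expectation is therefore uncertain in direction, with a modest step most likely, and compound 4 is estimated at 500 nM in this assay, within 120 nM to 2500 nM, which corresponds to an expected step of a 1.2-fold higher number from compound 2 to compound 4 (0.08 log units; within the scatter).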

Compound 4, half-maximal inhibitory concentration: 12.1 nM
Compound 4: the middle estimate sits 41-fold (1.62 log units) above what was measured; the measured number lies below the stated range.
By their numbers in this assay, from the lowest: compound 4; then compound 3; then compound 1; then compound 2.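

In this assay, the position next to the ring nitrogen proves far more responsive than the chloro step alone suggested, with the replacement of (4-chlorobenzyl)amino by the six-membered non-aromatic ring giving a 34-fold lower number from compound 2 to compound 4 (1.53 log units; beyond the scatter). The chloro atom does not account for this gain, since the comparison without it still shows a 17-fold lower number from compound 1 to compound 4 (1.22 log units; beyond the scatter), so neither the six-membered aromatic ring of carbon only nor a hydrogen-bond donor in this group is required for a low number among the compounds shown. No supporting data tie the gain to the loss of the aromatic ring, the loss of the donor, the smaller group or the double bond.

Piperidine, the saturated ring without the double bond, and morpholine, with a ring oxygen added, would show how much depends on the double bond and on the ring's carbon framework, while a benzyl group on a tertiary amine nitrogen would separate the loss of the donor from the loss of the aromatic ring. As far as these compounds go, it also remains open how the two configurations at the carbon bearing the methyl group compare, as compound 4 is drawn without a defined configuration there.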